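This account rests on a few compounds, and the source may have more. Where it says the series, first, only, none or still open, it means among the compounds named here.

Of the compounds shown here, three sharing one core have been measured in an assay on cells for antagonist activity at transient receptor potential cation channel subfamily V member 1 (Homo sapiens), read by FLIPR and calcium flux, with a stated time of 6 min; a lower number here means a stronger inhibitor, a higher number a weaker inhibitor. Compound 1 `CC(C(=O)NCc1ccc(C(C)(C)C)nc1N1CCC(Cc2ccccc2)CC1)c1ccc(NS(C)(=O)=O)c(F)c1` gives 0.3 nM. Compound 2 `CCOc1nc(C(C)(C)C)ccc1CNC(=O)C(C)c1ccc(NS(C)(=O)=O)c(F)c1` gives 14.8 nM, and compound 3 `CCCOc1nc(C(C)(C)C)ccc1CNC(=O)C(C)c1ccc(NS(C)(=O)=O)c(F)c1` gives 1.7 nM. Among these three numbers compound 3 stands second: compound 1 lies lower and compound 2 lies higher, both beyond the scatter. Going by the values given here, the only single-point change measured so far is an 8.7-fold lower number from compound 2 to compound 3 (0.94 log units; beyond the scatter), a lengthening of the chain on the oxygen on the aromatic ring. Compound 4 `CC(C(=O)NCc1ccc(C(C)(C)C)nc1OC1CCCC1)c1ccc(NS(C)(=O)=O)c(F)c1` carries the change (cyclopentyl in place of propyl on an oxygen on an aromatic ring), which again enlarges the group on that oxygen, so the step from compound 2 to compound 3 is the one that bears on it, and it points toward a lower number. That earlier step lengthened a chain, whereas here a ring enters in its place, so whether the gain continues is open. The expected step is a 1.7-fold lower number from compound 3 to compound 4 (0.23 log units; within the scatter), a small lowering that stays within the scatter. Compound 4 is estimated to give 1 nM, with a range from 0.3 nM to 4 nM.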

Compound 4, inhibition constant: 1.5 nM
For compound 4 the middle estimate is 1.5-fold (0.18 log units) below the measured one, within the range that was stated.
By their numbers in this assay, from the lowest: compound 1; then compounds 4 and 3 (each within the scatter of the next); then compound 2.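

In this assay, replacing the open propyl chain with a ring gives a 1.1-fold lower number from compound 3 to compound 4 (0.05 log units; within the scatter), so on this oxygen on an aromatic ring, a five-membered carbon ring and the propyl chain cannot be told apart. Set against ethyl, cyclopentyl gives a 9.9-fold lower number from compound 2 to compound 4 (0.99 log units; beyond the scatter), which stands alongside an 8.7-fold lower number from compound 2 to compound 3 (0.94 log units; beyond the scatter) and leaves the ethyl compound apart from both larger groups. Nothing available here explains why propyl and cyclopentyl read alike or why ethyl reads differently.

The compounds shown leave open how a butyl chain or a cyclohexyl ring on this oxygen would read, and so whether larger groups would keep pace with these two. Also open, as far as these compounds go, is how a methoxyethyl chain, which carries a second oxygen, would compare with propyl.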